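Swapping the Chain-End Bicycle on a Weak Inhibitor

The source may report more compounds than this note shows. Statements on the series, on what has been measured and on what is new or still open speak of the compounds shown alone.

Of the compounds shown here, two sharing one core have been measured. Compound 1 `Cc1ccc(NC(=O)c2ncn(CC(=O)NCc3ccc4[nH]ncc4c3)n2)cc1C` gives 36900 nM in an assay for inhibition of histone-lysine N-methyltransferase, H3 lysine-79 specific (Homo sapiens), read by luminescence, with a stated time of 1 h (on this read-out lower numbers stand for stronger inhibition and higher numbers for weaker inhibition), and compound 2 `Cc1ccc(NC(=O)c2ncn(CC(=O)NCCn3ccc4c(N)ncnc43)n2)cc1C` gives 10900 nM in this assay, the lower of the two numbers and so the stronger inhibitor, with the gap to compound 1 lying beyond the usual scatter. Compound 3 `Cc1ccc(NC(=O)c2ncn(CC(=O)NCCn3cnc4[nH]ccc4c3=O)n2)cc1C` keeps the core and chain of compound 2 but exchanges the group at the chain end: a group of 10 heavy atoms (6 carbon, 3 nitrogen, 1 oxygen; one five-membered aromatic ring with 1 hetero atom, one six-membered aromatic ring with 2 hetero atoms) in place of a group of 10 heavy atoms (6 carbon, 4 nitrogen; one five-membered aromatic ring with 1 hetero atom, one six-membered aromatic ring with 2 hetero atoms), on a saturated chain carbon, two bonds along the chain from an amide-type nitrogen. Among the compounds with values here, no measured pair mirrors this exchange, so its effect is not known from the data. Because compound 2 already sits at a weak 10900 nM, and the exchange alters the part that distinguishes compound 2 from compound 1, a loss of potency beyond the scatter is expected, roughly a 3.2-fold higher number from compound 2 to compound 3 (0.51 log units; beyond the scatter). Compound 3 is estimated at 35000 nM, likely between 12000 nM and 100000 nM.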

Compound 3, half-maximal inhibitory concentration: 138000 nM
Beside the measured number, compound 3's estimate is 3.9-fold (0.60 log units) below it, outside the stated range (above it).
By their numbers in this assay, from the lowest: compound 2; then compound 1; then compound 3.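

Exchanging the group at the chain end gives a 13-fold higher number from compound 2 to compound 3 (1.10 log units; beyond the scatter) in this assay, so this position is sensitive to more than the overall shape of the group. The two groups have the same ring sizes, the same count of 10 heavy atoms and the same single hydrogen-bond donor; the entering group differs by swapping one nitrogen for an oxygen, having one hydrogen-bond acceptor fewer and carrying a double bond outside the aromatic rings. Nothing available explains why this exchange costs so much potency.

Which of these differences matters remains open, since both change together in this single pair. It is also unknown how a simple amine at the chain end, or a longer chain carrying the group of compound 2, would read in this assay.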